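Aminoquinoline series, permeability notes for compound 4

The source may report more compounds than this note shows. Statements on the series, on what has been measured and on what is new or still open speak of the compounds shown alone.

Of the compounds shown here, three of the shared core have been measured in an ADME assay for permeability, using PAMPA, with a stated time of 30 min, at pH 7.4; a higher number here means that the compound crosses the layer faster, a lower number that the compound crosses the layer more slowly. Compound 1 `COc1ccc(-c2ccc3c(NCCCNCc4cccc(OC)c4O)ccnc3c2)cc1` gives 237 10^-6 cm/s. Compound 2 `COc1cccc(Oc2ccc3c(NCCCNCc4ccco4)ccnc3c2)c1` gives 317 10^-6 cm/s. Compound 3 `Fc1ccc(Oc2ccc3c(NCCCNCc4ccco4)ccnc3c2)cc1` gives 317 10^-6 cm/s, level with compound 2 at the digits shown and together with it the highest of the three numbers; compound 1 sits furthest from compound 3, though still within the scatter of it.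

The next compound is compound 4 `COc1ccc(-c2ccc3c(NCCCNCc4ccco4)ccnc3c2)cc1`. The change from compound 3 is 4-methoxyphenyl in place of 4-fluorophenoxy on an aromatic carbon. Of the measured steps, only no change at the digits printed from compound 2 to compound 3 (within the scatter) bears on it, and that step exchanged one aryl group for another on the same oxygen without moving the number. The change here also removes the oxygen link, and compound 1 already carries the 4-methoxyphenyl directly on the core; its value lies close to that of compound 3 and within the scatter of it. Among the measured compounds shown here, no measured step therefore points to a shift beyond the scatter in this assay, and the step of a 1.1-fold lower number from compound 3 to compound 4 (0.04 log units; within the scatter) is expected to be small, with no firm direction. The estimate for compound 4 is 290 10^-6 cm/s, expected between 190 10^-6 cm/s and 440 10^-6 cm/s.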

Compound 4, apparent permeability: 237 10^-6 cm/s
Estimate against measurement, compound 4: 1.2-fold (0.09 log units) above; low and high end bracket the measured number.
By their numbers in this assay, from the lowest: compounds 1, 4, 2 and 3 (each within the scatter of the next).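

In this assay, the aromatic carbon of the shared core takes 4-methoxyphenyl in place of either aryloxy group with the number staying within the scatter (a 1.3-fold lower number from compound 3 to compound 4 (0.13 log units; within the scatter); a 1.3-fold lower number from compound 2 to compound 4 (0.13 log units; within the scatter)), so these steps add a change of the group attached directly to that carbon to the earlier exchange of one aryl group for another on the same oxygen. With 4-methoxyphenyl held at that carbon, furan-2-yl in place of 2-hydroxy-3-methoxyphenyl on the saturated chain carbon bound to an amine nitrogen also leaves the reading unmoved (no change at the digits printed from compound 1 to compound 4 (within the scatter)), a first view of that second site with this aryl group in place. Nothing measured offers an explanation for these small steps.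

Every step read here lies within the scatter, so the compounds shown do not reveal any change at either site that moves this assay beyond it. As far as these compounds go, whether a carboxylic acid or a primary amine at the aromatic carbon, or a longer chain in place of the present one, would do so remains open.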